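A few compounds are considered here, and "the series" means these few. Any claim that something is new, unique, unknown or untested is made for them only; others in the source may bear on it.

Measured so far in an ADME assay on MT4 cells (Homo sapiens) for cytotoxicity, read by MTT assay; a higher number here means that more compound is tolerated, a lower number that less compound is tolerated:
- compound 1 `O=C1c2ccccc2C(=O)N1CCOC(=S)N(C(=O)c1ccc(C(F)(F)F)cc1)c1ccc(Cl)cc1`: 10000 nM
- compound 2 `O=C1c2ccccc2C(=O)N1CCOC(=S)N(C(=O)c1ccc(Cl)c(Cl)c1)c1ccccc1`: 52000 nM

Within the data shown here, only these two compounds have numbers so far. Compound 2, at 52000 nM, holds the higher value, so cells tolerate more of it. Compound 1, at 10000 nM, lies lower, and that gap is beyond the usual scatter of repeated measurements.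

The next compound is compound 3 `O=C1c2ccccc2C(=O)N1CCOC(=S)N(C(=O)c1ccc(Cl)c([N+](=O)[O-])c1)c1ccccc1`, which keeps the shared core of compound 2 and changes one group: nitro in place of chloro on an aromatic carbon. In words, a nitro takes the place of a chloro on an aromatic carbon, turning the 3,4-dichlorophenyl into a 4-chloro-3-nitrophenyl.

Among the measured compounds shown here, no measured pair shows this swap on its own. Compound 1 and compound 2 differ in more than one place, so their values mark out a plausible range but do not give the size of this step. In this assay, no step beyond the scatter is expected, with a slight lean towards a lower number. The estimated step runs a 1.7-fold lower number from compound 2 to compound 3 (0.24 log units; within the scatter). For compound 3 the expected value is 30000 nM, with an estimated range of 9000 nM to 90000 nM.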

Compound 3, half-maximal cytotoxic concentration: 51000 nM
Beside the measured number, compound 3's estimate is 1.7-fold (0.23 log units) below it; low and high end bracket the measured number.
By their numbers in this assay, from the lowest: compound 1; then compounds 3 and 2 (each within the scatter of the next).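

Among these compounds, the measured step is a 1.0-fold lower number from compound 2 to compound 3 (0.01 log units; within the scatter) in this assay and gives the first direct reading of nitro in place of chloro on an aromatic carbon. The earlier pair differed in more than one place. At this place on the ring, ortho to a chloro group, the 3,4-dichlorophenyl and the 4-chloro-3-nitrophenyl cannot be told apart in how much compound the cells tolerate, even though the nitro brings more heavy atoms and more hydrogen-bond acceptors than the chloro it replaces. Nothing measured here offers an explanation for this match.

On these data alone, whether the same holds for other groups at this place, such as an amine, a carboxylic acid or a nitrile, remains open, and so does whether it holds when the chloro that stays on the ring is absent. Compound 1 still differs from compound 2 and compound 3 in more than one place, so which of its differences sets it apart also remains unresolved.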